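The compounds below may be only part of what the source reports. "The series", "measured", "known", "first", "only" and "open" are said of these compounds alone.

Compound 3 `COc1cc(NC(C)CCCNC(=O)NNC(=O)/C=C/c2ccc(OC)c(OC)c2)c2ncccc2c1` belongs to a small set built on the shared core of compound 1 `COc1cc(NC(C)CCCNC(=O)NC2CCCCC2)c2ncccc2c1`, and in an ADME assay on L6 cells (Rattus norvegicus) for cytotoxicity, read by resazurin assay, with a stated time of 70 h (on this read-out lower numbers stand for stronger inhibition and higher numbers for weaker inhibition), compound 1 gives "not determined" (no result reported). Compound 2 `COc1cc(NC(C)CCCNC(=O)NNC(=O)/C=C/c2ccccc2)c2ncccc2c1` carries a plain phenyl at the same place, and in this assay compound 2 gives 13900 nM. In this assay compound 3 gives 37000 nM, the highest of the two numbers available, and the step of a 2.7-fold higher number from compound 2 to compound 3 (0.43 log units; beyond the scatter) is modest but beyond the scatter. Compound 4 `COc1cc(NC(C)CCCNC(=O)NNC(=O)/C=C/c2ccc(C(F)(F)F)cc2)c2ncccc2c1` differs from compound 3 by 4-(trifluoromethyl)phenyl in place of 3,4-dimethoxyphenyl on a double-bonded chain carbon bound to a double-bonded chain carbon. Among the compounds with values here, only the step from compound 2 to compound 3 bears on this change, and it concerns a different replacement at the same place; no measured compound tells how a trifluoromethyl-bearing phenyl behaves here. The expected step is therefore a 1.7-fold lower number from compound 3 to compound 4 (0.23 log units; within the scatter), leaning towards a somewhat lower number but not clearly beyond the scatter. Compound 4 is accordingly estimated at 22000 nM, with a range from 8000 nM to 60000 nM.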

Compound 4, half-maximal inhibitory concentration: 28300 nM
Estimate against measurement, compound 4: 1.3-fold (0.11 log units) below, within the range that was stated.
By their numbers in this assay, from the lowest: compound 2; then compounds 4 and 3 (each within the scatter of the next).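

In this assay, 4-(trifluoromethyl)phenyl in place of 3,4-dimethoxyphenyl gives a 1.3-fold lower number from compound 3 to compound 4 (0.12 log units; within the scatter) and so separates these two substituted phenyl groups at this place no more than the usual scatter would. Trifluoromethyl in place of hydrogen on an aromatic carbon gives a 2.0-fold higher number from compound 2 to compound 4 (0.31 log units; beyond the scatter), so compound 3 and compound 4 both read higher than compound 2, each by a modest step, although their substituents differ. Nothing available gives a reason for these steps.

On these data alone, whether an amine or a carboxylic acid on this phenyl would leave the number in the same range remains open. As far as these compounds go, it is also open whether a longer chain between the phenyl and the carbonyl would change the reading.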